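The source may hold more compounds than are shown below. What is called first, only, known or untested is meant among the compounds shown, and "the series" means these compounds.

Compound 1 `CCCc1nnc(SCc2ccccc2)n1N1C(=O)c2ccccc2C1=O` in a functional assay on HepG2 cells (Homo sapiens) for cytotoxicity, read by MTT assay, with a stated time of 48 h (on this read-out lower numbers stand for stronger inhibition and higher numbers for weaker inhibition), gives > 200000 nM, which is a limit of the assay and not a number.
Compound 2 `C=CCSc1nnc(-c2cc(OC)c(OC)c(OC)c2)n1N1C(=O)c2ccccc2C1=O` in this assay gives > 200000 nM, again a limit.
Compound 3 `COc1cc(-c2nnc(SCC(=O)c3ccc(Cl)cc3)n2N2C(=O)c3ccccc3C2=O)cc(OC)c1OC` in this assay gives 22000 nM.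

Within the data shown here, compound 3 thus stands as the only number among the three values shown; the other two sit at the limit described by the limit of > 200000 nM in this assay, at which 2 of the 3 values shown sit. Compound 4 `COc1cc(-c2nnc(SCc3ccccc3)n2N2C(=O)c3ccccc3C2=O)cc(OC)c1OC` differs from compound 3 by phenyl in place of (4-chlorophenyl)carbonyl on a saturated chain carbon bound to a sulfur. Among the measured compounds shown here, one measured step bears on this change: an at least 9.0-fold lower number from compound 2 to compound 3 (0.95 log units; beyond the scatter), the step that brought the (4-chlorophenyl)carbonyl group in. Removing it again, toward a benzylsulfanyl group like that of compound 1, is expected to give back much of that difference. Compound 4 is therefore estimated at 100000 nM, within 30000 nM to 300000 nM, a step of a 4.5-fold higher number from compound 3 to compound 4 (0.66 log units; beyond the scatter) toward weaker inhibition, and quite possibly reported only as a limit.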

Compound 4, half-maximal inhibitory concentration: > 200000 nM
Compound 4 ended at the assay's limit (the forecaster's own chance of this, stated with the estimate: 50%); at least 2.0-fold (0.30 log units) between middle value and limit.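

In this assay the swap on a saturated chain carbon bound to a sulfur gives an at least 9.0-fold higher number from compound 3 to compound 4 (0.95 log units; beyond the scatter) with the 3,4,5-trimethoxyphenyl group held in place, so benzylsulfanyl, like the allylsulfanyl of compound 2, does not retain the measurable value of compound 3. The steps to compound 1 and compound 2 cannot be read, as both ends are limits. Compound 4 gives a limit and not a number: the limit of > 200000 nM in this assay, at which 3 of the 4 values shown sit.

The compounds shown do not separate the carbonyl from the chlorine in ((4-chlorophenyl)carbonyl)methyl. A phenylcarbonyl group without chlorine, or a 4-chlorobenzyl group, would bear on that question.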